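This account rests on a few compounds, and the source may have more. Where it says the series, first, only, none or still open, it means among the compounds named here.

In a functional assay on HCC827 cells (Homo sapiens) for inhibition, read by fluorescence, with a stated time of 72 h (a higher number here means a weaker inhibitor of growth, a lower number a stronger inhibitor of growth), compound 1 `N[C@H]1CC[C@H](Nc2nc(Nc3ccc(Cl)cc3)c3ncn(C4CCCCC4)c3n2)CC1` gives 9100 nM and compound 2 `COc1ccc(Cn2cnc3c(Nc4cccc(Cl)c4)nc(N[C@H]4CC[C@H](N)CC4)nc32)cc1` gives 18700 nM on the same shared core. Compound 3 `CC(C)CCn1cnc2c(NCc3cccc(Cl)c3)nc(N[C@H]3CC[C@H](N)CC3)nc21` stands at 16700 nM and so lies within the usual scatter of both others, which means these numbers place it neither ahead of nor behind either one.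

Compound 4 `CC(C)CCn1cnc2c(Nc3ccc(O)cc3)nc(N[C@H]3CC[C@H](N)CC3)nc21` has not yet been measured. It comes from compound 3 through a single change 4-hydroxyphenyl in place of 3-chlorobenzyl on a nitrogen on an aromatic ring in which 4-hydroxyphenyl replaces 3-chlorobenzyl on a nitrogen on an aromatic ring. The chlorine leaves, and a hydrogen-bond donor and acceptor enter.

Among the measured compounds shown here, no two measured compounds differ in only one place, so the data give no direct size for this swap. The closest guide is indirect. Compound 2 has its ring on that nitrogen without a carbon link and gives 18700 nM in this assay while compound 3 keeps the link and gives 16700 nM within the scatter of it. For the measured compounds named here, no measured compound carries a hydroxyl group, so the range must stay wide.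

The expectation is therefore no change beyond the scatter in either direction, an estimated 1.2-fold lower number from compound 3 to compound 4 (0.08 log units; within the scatter) in size. Compound 4 is estimated at 14000 nM with 5000 nM to 40000 nM as the expected range.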

Compound 4, concentration for 50% growth inhibition: 14400 nM
Compound 4: the middle estimate sits 1.0-fold (0.01 log units) below what was measured, and the stated range covers the measured number.
By their numbers in this assay, from the lowest: compounds 1, 4, 3 and 2 (each within the scatter of the next, the first and the last beyond it).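

In this assay, among the compounds shown here, this swap gives the first step that can be read at this position: a 1.2-fold lower number from compound 3 to compound 4 (0.06 log units; within the scatter) leaves no difference that can be told apart from repeat-to-repeat variation. Putting 4-hydroxyphenyl in place of 3-chlorobenzyl on a nitrogen on an aromatic ring therefore makes no readable difference to growth inhibition, even though the chlorine leaves and a hydrogen-bond donor and acceptor enter. The swap alters several features together, including the carbon link to the ring, and no other information here bears on how this outcome arises.

Compounds 3 and 4 alone cannot show whether the removal of the chlorine, the loss of the carbon link or the arrival of the hydroxyl has any effect of its own, or whether separate effects cancel in this pair. A plain phenyl on the same nitrogen would separate the link from the hydroxyl, while a carboxylic acid on that ring would test a quite different group at this position.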